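Adding a Dimethylamino Group to the Phenyl of Compound 1

The source may hold more compounds than are shown below. What is called first, only, known or untested is meant among the compounds shown, and "the series" means these compounds.

Of the compounds shown here, three sharing one core have been tested in a functional assay on ACHN cells (Homo sapiens) for antiproliferative activity, read by MTT assay, with a stated time of 96 h; a higher number here means a weaker inhibitor, a lower number a stronger inhibitor. Compound 1 `O=C1C2=C(C(=O)c3ncccc31)C1(CS2)NC(=O)N(c2ccccc2)C1=O` gives 21 nM, the lowest of the three numbers. Compound 3 `O=C1NC(=O)C2(CSC3=C2C(=O)c2ncccc2C3=O)N1` carries a hydrogen where the phenyl stands in its neighbour; in this assay compound 3 gives 80 nM. That change is a 3.8-fold higher number from compound 1 to compound 3 (0.58 log units; beyond the scatter). Within the data shown here, compound 2 `O=C1NN(c2ccc(Cl)cc2)C(=O)C2(CSC3=C2C(=O)c2ncccc2C3=O)N1` differs in more than one place from the others and so offers no single step to lean on; compound 2 gives 360 nM.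

Compound 4 `CN(C)c1ccc(N2C(=O)NC3(CSC4=C3C(=O)c3ncccc3C4=O)C2=O)cc1` is compound 1 with one change: dimethylamino in place of hydrogen on an aromatic carbon. Among the measured compounds shown here, no measured step adds a group to this phenyl; the only step at hand, a 3.8-fold higher number from compound 1 to compound 3 (0.58 log units; beyond the scatter), removes the phenyl altogether and shows only that the ring counts for something modest. Adding a small group to a ring that stays in place is a different matter, and nothing here compares directly. Compound 4 is therefore expected to move by only a 1.4-fold higher number from compound 1 to compound 4 (0.15 log units; within the scatter), a step not expected to exceed the scatter. Compound 4 is estimated at 30 nM, with a range from 10 nM to 90 nM.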

Compound 4, half-maximal inhibitory concentration: 90 nM
Beside the measured number, compound 4's estimate is 3.0-fold (0.48 log units) below it, within the range that was stated.
By their numbers in this assay, from the lowest: compound 1; then compounds 3 and 4 (each within the scatter of the next); then compound 2.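

In this assay the phenyl of compound 1 proves sensitive to substitution: placing dimethylamino on an aromatic carbon, para to a large group, gives a 4.3-fold higher number from compound 1 to compound 4 (0.63 log units; beyond the scatter) and so costs about as much as the earlier loss of the whole phenyl. The step of a 1.1-fold higher number from compound 3 to compound 4 (0.05 log units; within the scatter) lies within the scatter, so the 4-(dimethylamino)phenyl group offers no measurable edge over a bare hydrogen on that ring nitrogen, and the advantage that plain phenyl holds in compound 1 is absent. No measurement available here accounts for this shift. From the compounds shown here alone, it remains open whether the cost belongs to dimethylamino itself or to any group at this carbon, which a fluorine, a methoxy or a carboxylic acid there could help separate. Also open, going by these compounds, is how dimethylamino would behave on another carbon of the phenyl.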